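The source may hold more compounds than are shown below. What is called first, only, known or untested is meant among the compounds shown, and "the series" means these compounds.

Antiproliferative series, measured in a functional assay on HT-29 cells (Homo sapiens) for antiproliferative activity, read by MTT assay, with a stated time of 72 h; on this read-out lower numbers stand for stronger inhibition and higher numbers for weaker inhibition:

- compound 1 `COc1cc2c(Oc3ccc(NC(=O)C4(c5nnc(-c6ccc(F)cc6)o5)CC4)cc3F)ccnc2cc1OCCCN1CCCC1`: 779 nM
- compound 2 `COc1cc2c(Oc3ccc(NC(=O)c4cc(-c5ccc(F)cc5)on4)cc3)ccnc2cc1OCCCN1CCC(C)CC1`: 24600 nM
- compound 3 `COc1cc2nccc(Oc3ccc(NC(=O)c4ncc(-c5ccc(F)cc5)o4)cc3)c2cc1OC`: > 100000 nM (a limit of the assay, not a number)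

Of the two numeric results, compound 2, at 24600 nM, holds the higher value and thus the weaker inhibition. Compound 1, at 779 nM, lies lower, by more than the usual scatter. Compound 3 gives only a limit, > 100000 nM.

The next compound to be tested is compound 4 `COc1cc2c(Oc3ccc(NC(=O)c4nnc(-c5ccc(F)cc5)o4)cc3)ccnc2cc1OCCCN1CCC(C)CC1`. Compared with compound 2, it carries 5-(4-fluorophenyl)-1,3,4-oxadiazol-2-yl in place of 5-(4-fluorophenyl)-1,2-oxazol-3-yl on a carbonyl carbon.

Within the data shown here, no pair of measured compounds differs in one place only, so this assay offers no direct precedent for this change. Among the measured compounds shown here, the one measured compound with the same 5-(4-fluorophenyl)-1,3,4-oxadiazol-2-yl group is compound 1, at 779 nM, but it differs from compound 2 elsewhere too, so it is weak support. A moderate move towards lower numbers is therefore expected in this assay, with a result within the scatter still possible. The expected change is a 2.5-fold lower number from compound 2 to compound 4 (0.39 log units; beyond the scatter). For compound 4 the estimate is 10000 nM, with an expected range of 2000 nM to 50000 nM.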

Compound 4, half-maximal inhibitory concentration: 7890 nM
Beside the measured number, compound 4's estimate is 1.3-fold (0.10 log units) above it; the measured number falls inside the stated range.
By their numbers in this assay, from the lowest: compound 1; then compound 4; then compound 2. At a limit, above all of these: compound 3.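

In this assay, the change on a carbonyl carbon whose other neighbours are an amide-type nitrogen now has a direct reading: 5-(4-fluorophenyl)-1,3,4-oxadiazol-2-yl in place of 5-(4-fluorophenyl)-1,2-oxazol-3-yl gives a 3.1-fold lower number from compound 2 to compound 4 (0.49 log units; beyond the scatter) as a modest step. The two groups share the 4-fluorophenyl ring and differ in the five-membered aromatic ring, and the rest of the structure is held fixed, so this step reads that ring exchange alone. This single pair gives the size and direction of the step, but no measurement shown accounts for it.

Among these compounds, whether the exchange gives a step of similar size with another side chain, such as a morpholine in place of the 4-methylpiperidine, remains open, as this pair is the only reading of the change. Also open, going by these compounds, is how a 1,3,4-thiadiazol-2-yl group, with sulfur in place of the ring oxygen, would read at this position on a carbonyl carbon.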